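The source may hold more compounds than are shown below. What is called first, only, known or untested is meant among the compounds shown, and "the series" means these compounds.

Of the compounds shown here, three built on one shared core have been tested in a functional assay on L02 cells (Homo sapiens) for inhibition, read by Griess assay, with stated times of 1 h and 24 h; a lower number here means a stronger inhibitor, a higher number a weaker inhibitor. For compound 1 `CN(c1ccccc1)c1nc(/C=C/c2ccccc2)nc2ccsc12` the outcome is only a limit, > 1000000 nM. For compound 2 `Clc1ccc(CNc2nc(/C=C/c3ccco3)nc3ccsc23)cc1` the outcome is again a limit, > 1000000 nM. Among the compounds with values here, compound 3 `COc1ccc(Nc2nc(/C=C/c3cc(OC)c(OC)c(OC)c3)nc3ccsc23)cc1` is the one compound that gives a number, and in this assay compound 3 gives 279000 nM. The two other results stand at the limit of > 1000000 nM in this assay, at which 2 of the 3 values shown sit, so compound 3 is the only fixed point among the numbers shown.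

Compound 4 `COc1cc(/C=C/c2nc(NC(C)C)c3sccc3n2)cc(OC)c1OC` has not yet been measured in this assay. It differs from compound 3 in a single place: isopropyl in place of 4-methoxyphenyl on a nitrogen on an aromatic ring. Within the data shown here, no pair of measured compounds differs in one place, so there is no measured step to lean on, and the change cannot be read off from the other two compounds. Compound 4 is expected to stay close to compound 3 or to weaken, a step of a 1.6-fold higher number from compound 3 to compound 4 (0.21 log units; within the scatter) that may fall within the scatter or run toward the limit. Compound 4 is estimated in this assay at 450000 nM, with a range from 150000 nM to 1000000 nM.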

Compound 4, half-maximal inhibitory concentration: > 1000000 nM
Compound 4 ended at the assay's limit; the forecaster's own chance of this, stated with the estimate: 40%; middle value at least 2.2-fold (0.34 log units) away from the limit.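

Isopropyl in place of 4-methoxyphenyl on this nitrogen gives an at least 3.5-fold higher number from compound 3 to compound 4 (0.55 log units; beyond the scatter) in this assay and so weakens inhibition by more than the usual scatter. Within the data shown here, this is the first measured step between two compounds that differ in one place, and it shows that the group on this nitrogen affects the result when the rest of compound 3 is kept. From the compounds shown here alone, compound 4 gives a limit rather than a number, so the full size of the step stays unknown, and the limit now holds for most of the set: the limit of > 1000000 nM in this assay, at which 3 of the 4 values shown sit.

Going by these compounds, what remains open is whether the ring itself or the methoxy group on it matters more. A plain phenyl or a cyclohexyl group on this nitrogen, with the rest of compound 3 unchanged, would help to separate the two.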